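The source may hold more compounds than are shown below. What is called first, only, known or untested is meant among the compounds shown, and "the series" means these compounds.

In a functional assay (strain AB) with Danio rerio as the target, read by microscopy, with a stated time of 1 h (on this read-out higher numbers stand for an effect only at larger amounts of compound and lower numbers for an effect already at smaller amounts), compound 1 `CCN1CCc2c(sc(NC(=O)Nc3ccccc3)c2C(N)=O)C1` gives only a limit, > 25000 nM. For the measured compounds named here, compound 2 `NC(=O)c1c(NC(=O)Nc2ccc(Cl)cc2)sc2c1CCN(CC1CCCCC1)C2` is the one compound here with an actual number: in this assay compound 2 gives 1890 nM. Compound 3 `CC(C)(C)OC(=O)CCCN1CCc2c(sc(NC(=O)Nc3ccc(Cl)cc3)c2C(N)=O)C1` differs from compound 2 in a single place: 2-(tert-butoxycarbonyl)ethyl in place of cyclohexyl on a saturated chain carbon bound to an amine nitrogen in a ring. Going by the values given here, no pair of measured compounds shows what such a swap does on the shared core, so the size of the step is uncertain; in this assay the step is expected to run beyond the usual scatter toward higher numbers, a 3.2-fold higher number from compound 2 to compound 3 (0.50 log units; beyond the scatter). Compound 3 is therefore estimated to give 6000 nM in this assay, within a range from 1500 nM to 25000 nM.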

Compound 3, half-maximal effective concentration: 560 nM
For compound 3 the middle estimate is 11-fold (1.03 log units) above the measured one; measured number below the stated range.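

In this assay, putting 2-(tert-butoxycarbonyl)ethyl in place of cyclohexyl gives a 3.4-fold lower number from compound 2 to compound 3 (0.53 log units; beyond the scatter). So at this place on the saturated chain carbon bound to an amine nitrogen in a ring, a cyclohexyl ring is not required, and a larger group with no ring and with hydrogen-bond acceptors is accepted. Nothing measured here explains this step.

From the compounds shown here alone, it remains open whether the chain or its tert-butoxycarbonyl end accounts for the step. A plain pentyl chain or the free carboxylic acid at this place would separate the two.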